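Furan-2-yl amide in the thiazole anilide series

The compounds below may be only part of what the source reports. "The series", "measured", "known", "first", "only" and "open" are said of these compounds alone.

Measured compounds:
compound 1 `CCOC(=O)c1sc(-c2cccc(NC(=O)c3ccc(C(F)(F)F)cc3)c2)nc1Nc1ccc(N2CCN(C)CC2)cc1` — a functional assay on Raji cells (Homo sapiens) for antiproliferative activity, read by CCK-8 assay, with a stated time of 72 h; a higher number here means a weaker inhibitor, a lower number a stronger inhibitor: "not determined" (no result reported)
compound 2 `CCOC(=O)c1sc(-c2cccc(NC(=O)c3ccc(C#N)cc3)c2)nc1Nc1ccc(N2CCN(C)CC2)cc1` — this assay: 14000 nM
compound 3 `CCOC(=O)c1sc(-c2cccc(NC(=O)c3ccc(F)c(Cl)c3)c2)nc1Nc1ccc(N2CCN(C)CC2)cc1` — this assay: "not determined" (no result reported)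

Only compound 2 carries a number in this assay, 14000 nM, and that number sits at the weak end of what the read-out covers. Compound 3 has no single number in this assay, and compound 1 is a second entry without one, so compound 3 cannot be placed against any measured neighbour. Among the measured compounds shown here, no step between measured compounds exists within the set.

Compound 4 `CCOC(=O)c1sc(-c2cccc(NC(=O)c3ccco3)c2)nc1Nc1ccc(N2CCN(C)CC2)cc1` differs from compound 3 in one place: furan-2-yl in place of 3-chloro-4-fluorophenyl on a carbonyl carbon. For the measured compounds named here, with no measured step to lean on, the expectation for the step from compound 3 to compound 4 in this assay is none beyond the scatter, in either direction. Going by the values given here, the one anchor is compound 2 at 14000 nM, which shares the core of compound 4.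

Compound 4 is therefore estimated at 15000 nM in this assay, with a range from 4000 nM to 60000 nM, and a fair chance that only a limit is reported.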

Compound 4, half-maximal inhibitory concentration: 15100 nM
Beside the measured number, compound 4's estimate is 1.0-fold (0.00 log units) below it; the range from low to high includes it.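

In this assay, this amide position now has a second reading: a 1.1-fold higher number from compound 2 to compound 4 (0.03 log units; within the scatter), with furan-2-yl in place of 4-cyanophenyl on a carbonyl carbon. A five-membered aromatic ring and a six-membered one on this carbonyl therefore give values within the scatter of each other, so for this pair the exchange leaves the read-out unmoved. The change from 3-chloro-4-fluorophenyl to furan-2-yl itself cannot be read, as compound 3 carries no single number.

Going by these compounds, whether any group on this carbonyl can move the value beyond the scatter stays open, for example a simple alkyl chain or a morpholine ring in place of the aromatic ring. Also open, on these data alone, is what a carboxylic acid in place of the ethyl ester would do to the reading. No measured evidence bears on this result.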